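The source may hold more compounds than are shown below. What is called first, only, known or untested is meant among the compounds shown, and "the series" means these compounds.

Working notes on the series. In a functional assay on A-427 cells (Homo sapiens) for cytotoxicity, read by colorimetric assay and MTT assay (on this read-out lower numbers stand for stronger inhibition and higher numbers for weaker inhibition), compound 1 (`CCOC(=O)Cn1c(=O)c(-c2ccc(OC)cc2)cc2c(OC)cc(OC)cc21`) gives 10000 nM, and compound 2 (`COc1ccc(-c2cc3c(OC)cc(OC)cc3n(CCC#N)c2=O)cc1`) gives 10000 nM, so compound 2 stands level with compound 1 at the digits shown.

Compound 3 (`COc1ccc(-c2cc3c(OC)cc(OC)cc3n(CCC(=O)OCc3ccccc3)c2=O)cc1`) has not yet been measured. It carries benzyloxycarbonyl in place of cyano on a saturated chain carbon, two bonds along the chain from an aromatic nitrogen.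

Within the data shown here, only one measured step bears on this change: no change at the digits printed from compound 1 to compound 2 (within the scatter). That step exchanged ethoxycarbonyl and cyanomethyl on the same chain and lies within the scatter. Among the measured compounds shown here, compound 1 shows an ester on this chain at 10000 nM, but no measured compound carries the aromatic ring that enters here, so the evidence is thin. On the strength of that single step, no change beyond the scatter is expected in this assay, and no direction is favoured. The expected step is no change at the digits printed from compound 2 to compound 3 (within the scatter). For compound 3 the estimated value is 10000 nM, with an expected range of 3000 nM to 20000 nM.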

Compound 3, half-maximal inhibitory concentration: 10000 nM
The estimate for compound 3 equals the measured number at the digits printed, and the stated range covers the measured number.
By their numbers in this assay, from the lowest: compounds 1, 2 and 3 (each within the scatter of the next).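

In this assay, the change from cyano to benzyloxycarbonyl on a saturated chain carbon, two bonds along the chain from an aromatic nitrogen, gives no change at the digits printed from compound 2 to compound 3 (within the scatter). The wider comparison gives no change at the digits printed from compound 1 to compound 3 (within the scatter). The earlier pair covered only an ester and a nitrile without a ring on this chain, whereas this result adds a six-membered aromatic ring of carbon only and still shows no step beyond the scatter among the three compounds. No available evidence accounts for this absence of a step.

The compounds shown leave open whether an amine, a free carboxylic acid, an amide or a longer chain at this position would separate from these three values. With no step beyond the scatter so far, they also give no sign of which change to the shared core, if any, would move the read-out in this assay.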